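A few compounds are considered here, and "the series" means these few. Any claim that something is new, unique, unknown or untested is made for them only; others in the source may bear on it.

The measured compounds, in a functional assay on SR cells (Homo sapiens) for cytotoxicity, read by sulforhodamine B assay, with a stated time of 48 h, tested at 1 uM; on this read-out lower numbers stand for a stronger effect and higher numbers for a weaker effect at the one concentration tested:
Compound 1 `COc1ccc(-c2cc(/C=C/C(=O)c3ccc(N)cc3)[nH]n2)cc1` gives 45%.
Compound 2 `COc1cc(-c2cc(/C=C/C(=O)c3ccc(N)cc3)[nH]n2)cc(OC)c1OC` gives 14%.
Compound 3 `COc1cc(-c2cc(/C=C/C(=O)c3ccc(F)c(F)c3)[nH]n2)cc(OC)c1OC` gives 84%.

Compound 2 holds the lowest number of the three, and so the strongest effect at the one concentration tested. Its nearest neighbour is compound 1, a number beyond the scatter higher, and its furthest is compound 3. Among the measured compounds shown here, the one step recorded at a single position is a number 70 percentage points higher from compound 2 to compound 3 (beyond the scatter), a large loss of effect on putting 3,4-difluorophenyl in place of 4-aminophenyl on a carbonyl carbon.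

Compound 4 `COc1ccc(-c2cc(/C=C/C(=O)c3ccc(N)cc3)[nH]n2)cc1OC` is compound 2 with hydrogen in place of methoxy on an aromatic carbon. For the measured compounds named here, no measured step changes a methoxy group alone, so the step from compound 2 to compound 3 does not bear on this change directly. Compound 1, with one methoxy group where compound 2 has three, gives a higher number, though compound 1 and compound 2 differ in more than one place. The expected direction is therefore a modest rise, a number 14 percentage points higher from compound 2 to compound 4 (beyond the scatter), a little beyond the scatter but far short of the step to compound 3. Compound 4 is estimated at 28% on this assay, within 12% to 48%.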

Compound 4, a percentage reported as activity, at one concentration (the size of the read-out at that concentration, not a potency): 34%
Compound 4: the middle estimate sits 6 percentage points below what was measured; low and high end bracket the measured number.
By their numbers in this assay, from the lowest: compound 2; then compound 4; then compound 1; then compound 3.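

In this assay, among the compounds shown here, the methoxy group can now be read on its own, which the earlier compounds did not allow: putting hydrogen in place of methoxy on an aromatic carbon, ortho to a methoxy group and meta to a large group, gives a number 20 percentage points higher from compound 2 to compound 4 (beyond the scatter), while putting methoxy in place of hydrogen on an aromatic carbon gives a number 11 percentage points lower from compound 1 to compound 4 (beyond the scatter). Among the three compounds carrying 4-aminophenyl on the carbonyl carbon, each added methoxy group therefore goes with a lower number and a stronger effect, with none of the three going against this, and both steps are modest beside the large a number 70 percentage points higher from compound 2 to compound 3 (beyond the scatter). No evidence is available on why the methoxy groups act in this way.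

The compounds shown leave open whether a hydroxyl group, an ethoxy group or a fluorine atom at this aromatic carbon would serve as methoxy does. They also leave open whether the same methoxy steps would hold with 3,4-difluorophenyl in place of 4-aminophenyl on the carbonyl carbon.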